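This account rests on a few compounds, and the source may have more. Where it says the series, first, only, none or still open, it means among the compounds named here.

In a functional assay on CCRF-CEM cells (Homo sapiens) (on this read-out lower numbers stand for stronger inhibition and higher numbers for weaker inhibition), compound 1 `Nc1ncnc2c1ncn2C[C@@H]1C[C@H](CO)c2ccccc21` gives 24 ug/mL, compound 2 `Cc1ccc(-c2ncnc3c2ncn3C[C@@H]2C[C@H](CO)c3ccccc32)cc1` gives 1.4 ug/mL and compound 3 `OC[C@H]1C[C@@H](Cn2cnc3c(Cl)ncnc32)c2ccccc21` gives 24 ug/mL. Compound 3 therefore shares the highest of the three numbers with compound 1. Compound 4 `OC[C@H]1C[C@@H](Cn2cnc3c(O)ncnc32)c2ccccc21` carries hydroxy in place of chloro on an aromatic carbon. Two measured steps involve this same carbon. Chloro in place of amino gave no change at the digits printed from compound 1 to compound 3 (within the scatter), while chloro in place of 4-methylphenyl gave a 17-fold higher number from compound 2 to compound 3 (1.23 log units; beyond the scatter). Hydroxy is not an aryl group, so the amino-to-chloro step is the closer guide, although no measured compound carries hydroxy. The expected change is a 1.3-fold higher number from compound 3 to compound 4 (0.10 log units; within the scatter), with no step beyond the scatter in this assay. For compound 4 the estimated value is 30 ug/mL, within an expected range of 10 ug/mL to 80 ug/mL.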

Compound 4, half-maximal inhibitory concentration: 24 ug/mL
Beside the measured number, compound 4's estimate is 1.3-fold (0.10 log units) above it, within the range that was stated.
By their numbers in this assay, from the lowest: compound 2; then compounds 1, 3 and 4 (each within the scatter of the next).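

In this assay, hydroxy behaves like the two earlier single-atom or small replacements at this aromatic carbon, with no change at the digits printed from compound 3 to compound 4 (within the scatter) and no change at the digits printed from compound 1 to compound 4 (within the scatter). Hydroxy, chloro and amino therefore stand level, although hydroxy brings a hydrogen-bond donor and acceptor that chloro lacks, and only compound 2 goes against this, with a 17-fold higher number from compound 2 to compound 4 (1.23 log units; beyond the scatter). Nothing measured here gives a reason for this pattern.

From the compounds shown here alone, whether the lower number of compound 2 needs the methyl or only the ring stays open. A plain phenyl, a longer chain such as butyl or a carboxylic acid on this carbon would help to separate these cases.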